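A few compounds are considered here, and "the series" means these few. Any claim that something is new, unique, unknown or untested is made for them only; others in the source may bear on it.

Measured compounds:
- compound 1 `O=C(O)CCc1ccc(C#CC2CCCC2)cc1`; in a functional assay on 1321-N1 cells for agonist activity at Free fatty acid receptor 1 (Homo sapiens), read by calcium flux, with a stated time of 0.4 s (on this read-out higher numbers stand for larger maximal responses and lower numbers for smaller maximal responses), compound 1 gives 94%
- compound 2 `C/C=C/C#Cc1ccc(CCC(=O)O)c(F)c1`; compound 2 gives 97%
- compound 3 `C/C(C#Cc1ccc(CCC(=O)O)c(F)c1)=C/CO`; compound 3 gives 105%

Compound 1 stands lowest of the three numbers. Its nearest neighbour is compound 2, whose value is three points higher, within the scatter, so the two cannot be ordered. The furthest is compound 3, whose value is higher, beyond the scatter. All three compounds share the same propanoic acid side chain on the core and carry their variable group on a triple-bonded carbon.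

The next compound, compound 4 `C=C(C)C#Cc1ccc(CCC(=O)O)cc1`, differs from compound 1 as follows:
1-methylethenyl in place of cyclopentyl on a triple-bonded carbon

For the measured compounds named here, only one measured step bears on a change at this position: a number 8 percentage points higher from compound 2 to compound 3 (within the scatter). That step exchanged one open-chain group for another on the triple-bonded carbon and left the maximal response essentially where it was. Going by the values given here, the change from compound 1 to compound 4 replaces a five-membered ring by a small open-chain group at the same position; the data hold no step of exactly this kind. Among the compounds with values here, on the single relevant step, no movement beyond the scatter is expected in this assay. Compound 4 is therefore estimated at 96%, with a range of 85% to 107%, meaning an expected step of a number 2 percentage points higher from compound 1 to compound 4 (within the scatter).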

Compound 4, largest response reached (reported as efficacy), in percent of the reference or control that the assay uses: 108%
Beside the measured number, compound 4's estimate is 12 percentage points below it; measured number outside the range, above it.
By their numbers in this assay, from the lowest: compounds 1, 2, 3 and 4 (each within the scatter of the next, the first and the last beyond it).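

In this assay, for the compounds shown here, the triple-bonded carbon now proves able to shift the maximal response beyond the scatter: the exchange gives a number 14 percentage points higher from compound 1 to compound 4 (beyond the scatter), while the only earlier step at this place, a number 8 percentage points higher from compound 2 to compound 3 (within the scatter), stayed within it. The new step removes the cyclopentyl ring with its 5 heavy atoms and brings in 1-methylethenyl with 3 heavy atoms, no ring and a double bond outside aromatic rings, so a ring on this carbon is not needed for a response of this size. Nothing available accounts for the size of this step.

A single step cannot separate the loss of the ring from the smaller heavy-atom count or from the entering double bond, and an isopropyl or cyclopropyl group on the triple-bonded carbon would be needed to tell these apart. From the compounds shown here alone, it also remains open whether the same exchange would hold on the fluorine-bearing core of compound 2 and compound 3, and whether an amine or a longer chain at this place would keep the response.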